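This account rests on a few compounds, and the source may have more. Where it says the series, first, only, none or still open, it means among the compounds named here.

Of the compounds shown here, three built on one shared core have been measured in a functional assay on MDA-MB-436 cells (Homo sapiens) for antiproliferative activity, read by MTT assay, with a stated time of 48 h (a higher number here means a weaker inhibitor, a lower number a stronger inhibitor), so far. There, compound 1 `CN1CCN(c2ccc(-c3cc4c(N5CCN(S(=O)(=O)/C=C/c6ccccc6)CC5)ncnc4s3)cc2)CC1` gives 8670 nM and compound 2 `COc1ccc(NC(=O)N2CCN(c3ncnc4sc(-c5ccc(N6CCN(C)CC6)cc5)cc34)CC2)cc1` gives 30100 nM as its result. Compound 3 `CN1CCN(c2ccc(-c3cc4c(N5CCN(C(=O)Nc6ccccc6F)CC5)ncnc4s3)cc2)CC1` gives 14300 nM as its number. Its gap on one side stays inside the scatter (a 1.6-fold higher number from compound 1 to compound 3 (0.22 log units; within the scatter)) and its gap on the other side goes just past it (a 2.1-fold lower number from compound 2 to compound 3 (0.32 log units; beyond the scatter)).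

Compound 4 `CN1CCN(c2ccc(-c3cc4c(N5CCN(C(=O)Nc6ccc(F)cc6F)CC5)ncnc4s3)cc2)CC1` differs from compound 3 by fluoro in place of hydrogen on an aromatic carbon at a single spot: fluoro in place of hydrogen on an aromatic carbon, which turns 2-fluorophenyl into 2,4-difluorophenyl. The closest evidence is the exchange of the whole aromatic group on that nitrogen, 2-fluorophenyl in place of 4-methoxyphenyl, and that step was only modest (a 2.1-fold lower number from compound 2 to compound 3 (0.32 log units; beyond the scatter)). Going by the values given here, no measured pair isolates one added fluoro, and this change is smaller than that exchange, so no step beyond the scatter is expected in this assay here. The expected result is a small one (a 1.1-fold lower number from compound 3 to compound 4 (0.04 log units; within the scatter)). The estimate for compound 4 is 13000 nM with an expected range of 6500 nM to 26000 nM for the measurement.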

Compound 4, half-maximal inhibitory concentration: 20200 nM
Compound 4: middle estimate off by 1.6-fold (0.19 log units), on the low side, within the range that was stated.
By their numbers in this assay, from the lowest: compounds 1, 3, 4 and 2 (each within the scatter of the next, the first and the last beyond it).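

In this assay, a single fluoro added to the aromatic ring of compound 3, para to a large group, gives a step that stays within the scatter (a 1.4-fold higher number from compound 3 to compound 4 (0.15 log units; within the scatter)), so this one added atom does not separate the two compounds. The 2,4-difluorophenyl and 4-methoxyphenyl groups on the amide-type nitrogen cannot be told apart either (a 1.5-fold lower number from compound 2 to compound 4 (0.17 log units; within the scatter)), whereas (2,4-difluorophenyl)carbamoyl in place of (2-phenylethenyl)sulfonyl gives a modest step beyond the scatter (a 2.3-fold higher number from compound 1 to compound 4 (0.37 log units; beyond the scatter)). No measurement at hand offers an explanation for the size of any of these steps.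

Still open, as far as these compounds go, is whether an amine or a nitrile at this same ring position would give a step beyond the scatter. Also open, from the compounds shown here alone, is how a longer chain between the amide-type nitrogen and the aromatic ring would change the result in this assay.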